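Group swap at the aromatic carbon: compound 3 to compound 4

This account rests on a few compounds, and the source may have more. Where it says the series, first, only, none or still open, it means among the compounds named here.

Three measured compounds share one core and differ only in the group on an aromatic carbon of a six-membered aromatic ring of carbon only. Compound 1 `Cc1ccccc1-c1ccc2[nH]ncc2c1` carries methyl, and in an assay on CHO-TREX cells for antagonist activity at transient receptor potential cation channel subfamily A member 1 (Homo sapiens), read by FLIPR and calcium flux, with a stated time of 10 min (a lower number here means a stronger inhibitor, a higher number a weaker inhibitor), compound 1 gives 7810 nM. Compound 2 `CCc1ccccc1-c1ccc2[nH]ncc2c1` carries ethyl; in this assay compound 2 gives 584 nM. Compound 3 `CC(C)(C)c1ccccc1-c1ccc2[nH]ncc2c1` carries tert-butyl; in this assay compound 3 gives 3400 nM, the second highest number of the three, closer to compound 1 than to compound 2. The measured steps are a 13-fold lower number from compound 1 to compound 2 (1.13 log units; beyond the scatter), a 2.3-fold lower number from compound 1 to compound 3 (0.36 log units; beyond the scatter) and a 5.8-fold higher number from compound 2 to compound 3 (0.77 log units; beyond the scatter).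

Compound 4 `N#Cc1ccccc1-c1ccc2[nH]ncc2c1` is reached from compound 3 by cyano in place of tert-butyl on an aromatic carbon. Among the compounds with values here, none of the measured steps exchanges an alkyl group for cyano; all three move only among methyl, ethyl and tert-butyl, so they do not bear directly on this change and give no direction for it. Within the data shown here, the three measured numbers span the interval between compound 2 and compound 1, and with no step involving cyano, a number inside that interval is expected for compound 4. Compound 4 is therefore estimated at 4000 nM, within 800 nM to 20000 nM. The expected step is a 1.2-fold higher number from compound 3 to compound 4 (0.07 log units; within the scatter), which may not exceed the scatter.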

Compound 4, half-maximal inhibitory concentration: 1290 nM
Estimate against measurement, compound 4: 3.1-fold (0.49 log units) above; measured number inside the range.
By their numbers in this assay, from the lowest: compound 2; then compound 4; then compound 3; then compound 1.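

Cyano gives the first reading at this aromatic carbon for a group that is not alkyl, and in this assay it improves on two of the alkyl groups, with a 2.6-fold lower number from compound 3 to compound 4 (0.42 log units; beyond the scatter) and a 6.1-fold lower number from compound 1 to compound 4 (0.78 log units; beyond the scatter) as the two steps. It does not match ethyl, however, as a 2.2-fold higher number from compound 2 to compound 4 (0.34 log units; beyond the scatter) shows, so compound 2 keeps the lowest number of the four and the order of the groups from the lowest number reads ethyl, cyano, tert-butyl, methyl. No measurement of any property of these groups accompanies the numbers, so the data offer no explanation for this order.

Among alkyl groups the series jumps from ethyl straight to tert-butyl, so it remains open whether an isopropyl or a longer chain such as n-propyl would give a number lower than that of compound 2 or would already lose ground toward compound 3. Within the data shown here, with cyano as the only group here that contains a heteroatom, it also remains open how a methoxy group, an amine or a carboxylic acid on this same carbon would read against the alkyl groups and cyano.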